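The source may report more compounds than this note shows. Statements on the series, on what has been measured and on what is new or still open speak of the compounds shown alone.

Measured compounds in an ADME assay on MDCK cells (Canis lupus familiaris) for cytotoxicity, read by microscopy; a higher number here means that more compound is tolerated, a lower number that less compound is tolerated:
compound 1, `CCOC(=O)c1c(C)nc(NCCCCNc2ccnc3cc(Cl)ccc23)nc1-c1ccccc1`: 800 nM
compound 2, `CCOC(=O)c1c(C)nc(NCCCNc2ccnc3cc(Cl)ccc23)nc1-c1ccccc1`: 800 nM
compound 3, `CCOC(=O)c1c(C)nc(NCCCCNc2ccnc3cc(Cl)ccc23)nc1C`: 4000 nM

Compound 2 stands level with compound 1 at the digits shown, the two together giving the lowest of the three numbers; the only step shown is the one from compound 1 to compound 3, a 5.0-fold higher number from compound 1 to compound 3 (0.70 log units; beyond the scatter), beyond the scatter and modest in size. Compound 4, `CCOC(=O)c1c(C)nc(NCCCNc2ccnc3cc(Cl)ccc23)nc1C`, differs from compound 2 as follows: methyl in place of phenyl on an aromatic carbon. This is the same replacement as between compound 1 and compound 3, so that single step is the one that bears on it. A rise of similar size in this assay is therefore expected, a 5.0-fold higher number from compound 2 to compound 4 (0.70 log units; beyond the scatter). Compound 4 is estimated at 4000 nM, with a range from 1600 nM to 10000 nM. Only one measured pair supports the transfer; it is assumed, not shown.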

Compound 4, minimum cytotoxic concentration: 20000 nM
For compound 4 the middle estimate is 5.0-fold (0.70 log units) below the measured one; measured number above the stated range.
By their numbers in this assay, from the lowest: compounds 1 and 2 (each within the scatter of the next); then compound 3; then compound 4.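

In this assay methyl in place of phenyl on this aromatic carbon also raises the number on the core of compound 2, with a 25-fold higher number from compound 2 to compound 4 (1.40 log units; beyond the scatter) as the step, so the direction holds on both cores. The size of the rise does not carry over from one core to the other: the same change on two cores in this assay, a 5.0-fold higher number (0.70 log units; beyond the scatter) from compound 1 to compound 3 and a 25-fold higher number (1.40 log units; beyond the scatter) from compound 2 to compound 4, 5.0-fold (0.70 log units) apart, beyond the scatter of two such steps. The two chains print level with phenyl, whereas with methyl compound 3 at 4000 nM and compound 4 at 20000 nM stand apart.

The compounds shown leave open how an amine or a carboxylic acid at this position would read. They also leave open whether a longer chain would continue the trend seen with methyl.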